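Oxime ether chain substituents: methoxy to methylamino

The source may hold more compounds than are shown below. What is called first, only, known or untested is meant among the compounds shown, and "the series" means these compounds.

Compound 1 `CCCO/N=C/c1c(N)ncnc1Oc1ccc2[nH]c(C)cc2c1F`, compound 2 `Cc1cc2c(F)c(Oc3ncnc(N)c3/C=N/OCCCO)ccc2[nH]1` and compound 3 `COCCO/N=C/c1c(N)ncnc1Oc1ccc2[nH]c(C)cc2c1F` share one core and differ only at the end of the oxime ether chain. In a functional assay on HCT-116 cells (Homo sapiens) for antiproliferative activity (a lower number here means a stronger inhibitor, a higher number a weaker inhibitor), compound 1 gives 30 nM, compound 2 gives 452 nM and compound 3 gives 387 nM. Compound 3 therefore holds the second highest of the three numbers; its nearest neighbour is compound 2, within the scatter, its furthest compound 1, from which it is separated by a 13-fold higher number from compound 1 to compound 3 (1.11 log units; beyond the scatter).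

Compound 4 `CNCCO/N=C/c1c(N)ncnc1Oc1ccc2[nH]c(C)cc2c1F` continues from compound 3 by methylamino in place of methoxy on a saturated chain carbon, two bonds along the chain from an oxygen on an unsaturated carbon.

Among the measured compounds shown here, two measured steps bear on this. The step of a 13-fold higher number from compound 1 to compound 3 (1.11 log units; beyond the scatter) and the step of a 15-fold higher number from compound 1 to compound 2 (1.18 log units; beyond the scatter) both show that a polar terminal group on the chain raises the number by a large margin. The step of a 1.2-fold lower number from compound 2 to compound 3 (0.07 log units; within the scatter) shows that exchanging hydroxy for methoxy at that region leaves the number within the scatter. Methylamino, like hydroxy in compound 2, carries one hydrogen-bond donor and one acceptor, so compound 4 is expected to sit near compounds 2 and 3, with a step of a 1.1-fold lower number from compound 3 to compound 4 (0.04 log units; within the scatter) not beyond the scatter in this assay.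

Compound 4 is estimated at 350 nM, in the range 120 nM to 1000 nM.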

Compound 4, half-maximal inhibitory concentration: 3010 nM
For compound 4 the middle estimate is 8.6-fold (0.93 log units) below the measured one, and the stated range ends below it.
By their numbers in this assay, from the lowest: compound 1; then compounds 3 and 2 (each within the scatter of the next); then compound 4.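

In this assay, the methoxy and hydroxy chain ends of compound 3 and compound 2 stay within the scatter of each other, but the methylamino end does not join them: the exchange gives a 7.8-fold higher number from compound 3 to compound 4 (0.89 log units; beyond the scatter) and, on the other side, a 6.7-fold higher number from compound 2 to compound 4 (0.82 log units; beyond the scatter) at this same end of the oxime ether chain. Measured against the plain chain of compound 1, the result is a 100-fold higher number from compound 1 to compound 4 (2.00 log units; beyond the scatter) with the shared core unchanged, so the end of this chain alone spans a wide range of numbers, and compounds 2, 3 and 4 cannot be treated as one class of substituted chains. Nothing available gives a measured reason for the separate place of the methylamino end.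

From the compounds shown here alone, whether the step follows the nitrogen itself or the methylamino group as a whole remains open, and a primary amine, a dimethylamino end or a carboxylic acid on the same saturated chain carbon would help separate these readings. Also open, going by these compounds, is whether a longer chain between the oxime oxygen and the amine would keep the number of compound 4 or bring it back towards that of compound 1.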